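Swapping a Fluorinated Tail for an Ethoxy Chain

The compounds below may be only part of what the source reports. "The series", "measured", "known", "first", "only" and "open" are said of these compounds alone.

Compound 3 `CN(C)c1cc2[nH]c(C3CCCCC3)nc2cc1NC(=O)OCC(F)(F)F` is one of three closely related compounds tested in an ADME assay on Vero cells (Chlorocebus sabaeus) for cytotoxicity, read by resazurin assay, with a stated time of 3 days; on this read-out lower numbers stand for stronger inhibition and higher numbers for weaker inhibition. For compound 3 the result is only a limit, > 100 ug/mL. Compound 1 `CN(C)c1cc2[nH]c(C3CCCCC3)nc2cc1NC(=O)c1ccccc1` likewise gives only a limit, > 100 ug/mL. Compound 2 `CN(C)c1cc2[nH]c(C3CCCCC3)nc2cc1NC(=O)c1cccs1` also gives only a limit, > 100 ug/mL. All three sit at the limit of > 100 ug/mL in this assay, at which 3 of the 3 values shown sit, so the steps a step that the two limits leave unreadable from compound 1 to compound 2, a step that the two limits leave unreadable from compound 1 to compound 3 and a step that the two limits leave unreadable from compound 2 to compound 3 cannot be sized. Compound 4 `CCOCCOC(=O)Nc1cc2nc(C3CCCCC3)[nH]c2cc1N(C)C` differs from compound 3 by ethoxymethyl in place of trifluoromethyl on a saturated chain carbon bound to an oxygen next to a carbonyl group. Among the compounds with values here, since none of the measured steps can be read, no shift beyond the scatter is expected, and the estimated step is a step that the limit leaves unreadable from compound 3 to compound 4. Compound 4 is therefore expected to give 120 ug/mL in this assay, with a likely range from 50 ug/mL to 300 ug/mL.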

Compound 4, half-maximal inhibitory concentration: > 100 ug/mL
Compound 4 ended at the assay's limit; the forecaster's own chance of this, stated with the estimate: 75%; the middle value does not contradict the limit.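

No step from compound 1, compound 2 or compound 3 to compound 4 can be read, since all four compounds share one limit: the limit of > 100 ug/mL in this assay, at which 4 of the 4 values shown sit.

These compounds leave open at what concentration any of them would inhibit, and whether ethoxymethyl in place of trifluoromethyl would shift it.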